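Chloro on one benzyl arm: cytotoxicity expectation

The source may hold more compounds than are shown below. What is called first, only, known or untested is meant among the compounds shown, and "the series" means these compounds.

In a functional assay on HEL cells (Homo sapiens) for inhibition (a lower number here means that less compound is tolerated, a higher number that more compound is tolerated), compound 2 `O=C1c2ccccc2N(Cc2ccccc2)S(=O)(=O)N1Cc1ccccc1` reaches only the limit of > 200000 nM, not a number. Compound 1 `O=C1c2ccccc2N(Cc2ccccc2Cl)S(=O)(=O)N1Cc1ccccc1Cl` likewise sits at the limit of > 200000 nM in this assay. The evidence available is the limit of > 200000 nM in this assay, at which 2 of the 2 values shown sit. Compound 3 `O=C1c2ccccc2N(Cc2ccccc2)S(=O)(=O)N1Cc1ccccc1Cl` differs from compound 2 by chloro in place of hydrogen on an aromatic carbon; compound 1 carries chloro on both benzyl groups. Among the compounds with values here, no measured step between compounds differing in one place exists, so the expected step in this assay is a step that the limit leaves unreadable from compound 2 to compound 3, none beyond the scatter, since both neighbours rest at the limit (the limit of > 200000 nM in this assay, at which 2 of the 2 values shown sit). Compound 3 is therefore expected to remain at the limit, estimated at 250000 nM.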

Compound 3, half-maximal cytotoxic concentration: > 200000 nM
Compound 3 was reported as a limit (the forecaster's own chance of this, stated with the estimate: 90%); the middle value does not contradict the limit.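

Compound 1, compound 2 and compound 3 all sit at a limit in this assay, not at a number, so no step among them can be read: the limit of > 200000 nM in this assay, at which 3 of the 3 values shown sit.

The compounds shown leave open whether any change on the benzyl groups would give a readable half-maximal cytotoxic concentration in this assay.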